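This account rests on a few compounds, and the source may have more. Where it says the series, first, only, none or still open, it means among the compounds named here.

The measured compounds in an assay for inhibition of acid-sensing ion channel 3 (Homo sapiens), read by patch clamp, tested at 20 uM (a higher number here means more inhibition at the concentration tested (going by the name of the read-out), a lower number less inhibition), are these:
Compound 1, `C=CCNc1nc(N)c(C(=O)N=C(N)N)nc1Cl`: 78%
Compound 2, `CN1CCN(c2nc(N)c(C(=O)N=C(N)N)nc2Cl)CC1`: 51%
Compound 3, `NC(N)=NC(=O)c1nc(Cl)c(Nc2ccccn2)nc1N`: 25%

Compound 1 stands highest of the three in this assay; compound 2 comes nearest, a number 27 percentage points lower from compound 1 to compound 2 (beyond the scatter), and compound 3 lies furthest, a number 53 percentage points lower from compound 1 to compound 3 (beyond the scatter). Compound 4, `NC(N)=NC(=O)c1nc(Cl)c(NCc2ccccc2F)nc1N`, has not yet been measured. It differs from compound 1 thus: 2-fluorophenyl in place of vinyl on a saturated chain carbon bound to a nitrogen on an aromatic ring. The step that bears on it is the large drop from compound 1 to compound 3, where pyridin-2-yl stood in place of allyl on a nitrogen on an aromatic ring. In compound 4 the ring enters on a saturated chain carbon bound to that nitrogen, not on the nitrogen, so a loss beyond the scatter but smaller than that one is expected, a number 20 percentage points lower from compound 1 to compound 4 (beyond the scatter). Compound 4 is therefore estimated at 58%, between 35% and 80%.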

Compound 4, a percentage reported as inhibition, at one concentration (the size of the read-out at that concentration, not a potency): 92%
For compound 4 the middle estimate is 34 percentage points below the measured one; measured number outside the range, above it.
By their numbers in this assay, from the lowest: compound 3; then compound 2; then compound 1; then compound 4.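

In this assay, the step of a number 14 percentage points higher from compound 1 to compound 4 (beyond the scatter) shows that the saturated chain carbon bound to a nitrogen on an aromatic ring accepts 2-fluorophenyl, with its seven heavy atoms, in place of vinyl with no loss. The drop seen with pyridin-2-yl on the nitrogen, a number 53 percentage points lower from compound 1 to compound 3 (beyond the scatter), therefore does not extend to every aromatic ring in this substituent. On these data alone, it remains open whether plain phenyl in place of 2-fluorophenyl would give a similar number, and how a longer chain carrying the ring would fare. Nothing measured here accounts for the rise.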